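Anilide swap on the shared core: hydroxy for trifluoromethyl

A few compounds are considered here, and "the series" means these few. Any claim that something is new, unique, unknown or untested is made for them only; others in the source may bear on it.

Compound 1 `O=C(Nc1cccc(O)c1)C1c2ccccc2CCN1C(=O)c1ccc(Cl)cc1` and compound 2 `O=C(Nc1cccc(C(F)(F)F)c1)C1c2ccccc2CCN1C(=O)c1ccc(Cl)cc1` share the core and differ only in the anilide substituent. In a functional assay on NUGC-3 cells (Homo sapiens) for inhibition, read by sulforhodamine B assay, with a stated time of 48 h (a higher number here means a weaker inhibitor of growth, a lower number a stronger inhibitor of growth), compound 1 gives > 10000 nM, a limit of the assay. In this assay compound 2 likewise gives > 10000 nM, again a limit. The step that the two limits leave unreadable from compound 1 to compound 2 is therefore unreadable, as the limit of > 10000 nM in this assay, at which 2 of the 2 values shown sit, shows. Compound 3 `O=C(Nc1ccc(O)cc1)C1c2ccccc2CCN1C(=O)c1ccc(Cl)cc1` carries the change (4-hydroxyphenyl in place of 3-(trifluoromethyl)phenyl on an amide-type nitrogen). Among the compounds with values here, the only measured step that bears on it is a step that the two limits leave unreadable from compound 1 to compound 2, and it gives no size; 4-hydroxyphenyl on the amide-type nitrogen has not been measured on this core. Within the data shown here, no measured step supports an expectation of movement beyond the scatter in this assay. Essentially no step is expected, a step that the limit leaves unreadable from compound 2 to compound 3. Compound 3 is thus expected to give around 15000 nM in this assay, within 4000 nM to 60000 nM, most likely again reported only as a limit.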

Compound 3, concentration for 50% growth inhibition: > 10000 nM
Compound 3: only a limit was reported (the forecaster's own chance of this, stated with the estimate: 80%); the middle value is on the limit's open side.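

No step can be read among compound 1, compound 2 and compound 3, since each is reported only as a limit: the limit of > 10000 nM in this assay, at which 3 of the 3 values shown sit.

In this assay the compounds shown leave open whether any anilide substituent on the shared core gives a growth-inhibition value readable as a number.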